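Replacing the amino group of compound 1 with a second selenium chain

The source may hold more compounds than are shown below. What is called first, only, known or untested is meant among the compounds shown, and "the series" means these compounds.

Measured in a functional assay on HT-29 cells (Homo sapiens) for cytotoxicity, read by MTT assay, with a stated time of 72 h; on this read-out higher numbers stand for weaker inhibition of growth and lower numbers for stronger inhibition of growth:
- compound 1 `CCCCC[Se]c1nc(N)c2ccccc2n1`: > 100000 nM, which is a limit of the assay and not a number.
- compound 2 `C[Se]c1nc(N)c2ccccc2n1`: 74800 nM.
- compound 3 `Nc1nc([SeH])nc2ncccc12`: 89600 nM.

Compound 1 stands at the limit of > 100000 nM in this assay, at which 1 of the 3 values shown sits; for compound 1 only that limit is known. Compound 2 and compound 3 both give weak numbers, and no step between them is shown, so only their two values stand. Among the measured compounds shown here, the one measured step, an at least 1.3-fold lower number from compound 1 to compound 2 (0.12 log units; that floor lies within the scatter), lies within the scatter.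

Compound 4 `CCCCC[Se]c1nc([Se]CCCCC)c2ccccc2n1` differs from compound 1 by a group of 6 heavy atoms (5 carbon, 1 selenium; no ring) in place of one nitrogen atom, on an aromatic carbon. For the measured compounds named here, no measured step touches the amino group, and none places a second group of 6 heavy atoms on the shared core; the step from compound 1 to compound 2 alters only the chain on the selenium atom and stays within scatter. The data therefore give no ground for a step beyond the scatter in this assay in either direction. Compound 4 is estimated at 90000 nM, with a range from 30000 nM to 250000 nM. The step this estimate implies, an at least 1.1-fold lower number from compound 1 to compound 4 (0.04 log units; that floor lies within the scatter), is expected to stay close to the limit shown for compound 1, with a fair chance that compound 4 again returns only a limit.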

Compound 4, concentration for total growth inhibition: > 100000 nM
Compound 4: a limit, no number; the forecaster's own chance of this, stated with the estimate: 50%; at least 1.1-fold (0.04 log units) between middle value and limit.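

No step can be read from compound 1 to compound 4, since both values are limits of the assay and not numbers: the limit of > 100000 nM in this assay, at which 2 of the 4 values shown sit.

On these data alone, whether a group of 6 heavy atoms in place of the amino group changes growth inhibition on the shared core remains open.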